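Methyl on the benzyl ring of an inactive chromone

The compounds below may be only part of what the source reports. "The series", "measured", "known", "first", "only" and "open" are said of these compounds alone.

In a functional assay on A549 cells (Homo sapiens) for antiproliferative activity, read by sulforhodamine B assay, with a stated time of 72 h (on this read-out lower numbers stand for stronger inhibition of growth and higher numbers for weaker inhibition of growth), the values at hand are few. Compound 1 `Cc1cc(=O)oc2cc(SC3CCOC3=O)ccc12` reaches only a limit of the assay, > 36100 nM, as noted in the limit of > 36100 nM in this assay, at which 1 of the 3 values shown sits. Compound 2 `COC(=O)c1cccc(CSc2ccc3c(C)cc(=O)oc3c2)c1` gives a measured number, 7700 nM. Within the data shown here, compound 3 `CCc1cc(=O)c2ccc(OCc3ccccc3)c(C)c2o1` likewise reaches only a limit of the assay, > 33900 nM, as noted in the limit of > 33900 nM in this assay, at which 1 of the 3 values shown sits, so its true position is not fixed by a number and no step between measured compounds can be drawn from it.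

Compound 4 `CCc1cc(=O)c2ccc(OCc3cccc(C)c3)c(C)c2o1` differs from compound 3 by methyl in place of hydrogen on an aromatic carbon. Among the measured compounds shown here, no step between measured compounds is available to gauge such a change here, and the change is small, so no step beyond the usual scatter is expected in this assay in either direction; the most likely outcome is that compound 4 again reaches only a limit. Compound 4 is therefore expected to give about 40000 nM (range 15000 nM to 100000 nM), an expected step that the limit leaves unreadable from compound 3 to compound 4.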

Compound 4, concentration for 50% growth inhibition: 24900 nM
Beside the measured number, compound 4's estimate is 1.6-fold (0.21 log units) above it; low and high end bracket the measured number.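

In this assay the 3-methylphenyl ring of compound 4 gives this core a measured number, where the phenyl ring of compound 3 gave only a limit. The move reads as an at least 1.3-fold lower number from compound 3 to compound 4 (0.13 log units; that floor lies within the scatter) and so, on its printed floor alone, methyl in place of hydrogen on an aromatic carbon, meta to a large group, cannot be told from scatter. The true size of the step stays unknown because compound 3 stands at a limit of the assay: the limit of > 33900 nM in this assay, at which 1 of the 4 values shown sits.

Open, going by these compounds, is whether this same position would answer differently to a methoxy group, an amine or a carboxylic acid in place of the methyl. Also open, on these data alone, is whether compound 4 at 24900 nM would hold its number with the methyl moved elsewhere on the ring.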